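A few compounds are considered here, and "the series" means these few. Any claim that something is new, unique, unknown or untested is made for them only; others in the source may bear on it.

Of the compounds shown here, three have been measured. Compound 1 `C#CCNC1CCc2c(SCCc3ccc(Br)cc3)cccc21` gives 85300 nM in an assay on isolated protein for inhibition of Amine oxidase [flavin-containing] B (Homo sapiens); on this read-out lower numbers stand for stronger inhibition and higher numbers for weaker inhibition. Compound 2 `C#CCNC1CCc2c(SCCc3ccc(C)cc3)cccc21` gives 25800 nM. Compound 3 `C#CCNC1CCc2c(SCCc3cccc(Br)c3)cccc21` gives 30500 nM.

Among these, compound 3 has the second highest number: it is close to compound 2, the step being a 1.2-fold higher number from compound 2 to compound 3 (0.07 log units; within the scatter), and furthest from compound 1, with a 2.8-fold lower number from compound 1 to compound 3 (0.45 log units; beyond the scatter). Compound 4 `C#CCNC1CCc2c(SCCc3cccc(F)c3)cccc21` differs from compound 3 by fluoro in place of bromo on an aromatic carbon. Among the compounds with values here, no measured step exchanges one halogen for another; the closest guide is a 3.3-fold lower number from compound 1 to compound 2 (0.52 log units; beyond the scatter), where a smaller group took the place of bromo on the same ring and the number fell modestly. A modest fall is therefore expected here, within the same broad scale. Compound 4 is estimated at 20000 nM, with a range from 8000 nM to 60000 nM, which corresponds to an expected step of a 1.5-fold lower number from compound 3 to compound 4 (0.18 log units; within the scatter).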

Compound 4, half-maximal inhibitory concentration: 4300 nM
Beside the measured number, compound 4's estimate is 4.7-fold (0.67 log units) above it; measured number below the stated range.
By their numbers in this assay, from the lowest: compound 4; then compounds 2 and 3 (each within the scatter of the next); then compound 1.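

In this assay, within the data shown here, fluoro in place of bromo at this ring position gives a 7.1-fold lower number from compound 3 to compound 4 (0.85 log units; beyond the scatter) and so shows that the choice of halogen here can matter, a change the earlier compounds did not include. The 3-fluorophenyl group also compares well with the other two aryl groups, giving a 6.0-fold lower number from compound 2 to compound 4 (0.78 log units; beyond the scatter) and a 20-fold lower number from compound 1 to compound 4 (1.30 log units; beyond the scatter) and making compound 4 the strongest inhibitor of the four. No evidence here explains this gain.

Going by these compounds, whether chloro or a nitrile on the same ring carbon would give a number closer to compound 4 or to compound 3 remains open. So does whether fluoro would give a similar gain elsewhere on the ring.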